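Working notes: from compound 2 to compound 3

A few compounds are considered here, and "the series" means these few. Any claim that something is new, unique, unknown or untested is made for them only; others in the source may bear on it.

Compound 1 `Cc1ccc(OCC(=O)NNC(=O)c2cc3ccccc3oc2=O)c(C(=O)c2ccccc2Br)c1` gives 9400 nM
Compound 2 `Cc1ccc(OCC(=O)NNC(=O)c2cc3ccccc3oc2=O)c(C(=O)c2ccccc2Cl)c1` gives 47600 nM

In a functional assay on Ehrlich cells (Mus musculus) for cytotoxicity, read by LDH release, with a stated time of 48 h (a higher number here means a weaker inhibitor, a lower number a stronger inhibitor), compound 2 stands highest of the two with 47600 nM as its number. Compound 3 `Cc1ccc(OCC(=O)NNC(=O)c2cc3ccccc3oc2=O)c(C(=O)c2ccc(F)cc2)c1` follows with 4-fluorophenyl in place of 2-chlorophenyl on a carbonyl carbon as its change, 4-fluorophenyl in place of 2-chlorophenyl on a carbonyl carbon. Going by the values given here, the only measured step bearing on it is a 5.1-fold higher number from compound 1 to compound 2 (0.70 log units; beyond the scatter) and it is modest, with chloro in place of bromo on an aromatic carbon. That exchange fixes no direction here, and no step beyond the scatter is expected in this assay for this change. The expected step is a 1.4-fold lower number from compound 2 to compound 3 (0.13 log units; within the scatter) in this estimate. For compound 3 the estimated value is 35000 nM with 9000 nM to 120000 nM as its range.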

Compound 3, half-maximal inhibitory concentration: 40800 nM
Compound 3: the middle estimate sits 1.2-fold (0.07 log units) below what was measured; the measured number falls inside the stated range.
By their numbers in this assay, from the lowest: compound 1; then compounds 3 and 2 (each within the scatter of the next).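

In this assay, the exchange of 2-chlorophenyl for 4-fluorophenyl on a carbonyl carbon gives a 1.2-fold lower number from compound 2 to compound 3 (0.07 log units; within the scatter), so this change does not separate the two compounds. The step for 4-fluorophenyl in place of 2-bromophenyl is a 4.3-fold higher number from compound 1 to compound 3 (0.64 log units; beyond the scatter), which leaves compound 1 apart from both other compounds. No supporting data bear on why the 2-bromophenyl compound stands apart.

Compound 3 changes both the halogen and its printed ring number, so these two remain unseparated. As far as these compounds go, how an unsubstituted phenyl or a methoxyphenyl would read on that carbonyl carbon stays open.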